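The source may report more compounds than this note shows. Statements on the series, on what has been measured and on what is new or still open speak of the compounds shown alone.

Compound 1 `Cc1cc(NC(=O)Nc2ccccc2F)c2ccccc2n1`: 817 10^-6 cm/s
Compound 2 `Cc1cc(NC(=O)Nc2cccc(Cl)c2)c2ccccc2n1`: 566 10^-6 cm/s
Compound 3 `Cc1cc(NC(=O)Nc2ccc(Cl)cc2)c2ccccc2n1`: 537 10^-6 cm/s

These three share one core and differ only in the halogen on the ring attached to the amide-type nitrogen. In an ADME assay for permeability, using PAMPA, at pH 7.4 (a higher number here means that the compound crosses the layer faster, a lower number that the compound crosses the layer more slowly), compound 3 gives the lowest of the three numbers, yet the gaps a 1.1-fold lower number from compound 2 to compound 3 (0.02 log units; within the scatter) and a 1.5-fold lower number from compound 1 to compound 3 (0.18 log units; within the scatter) both lie within the scatter, so the three cannot really be told apart. Compound 4 `Cc1cc(NC(=O)Nc2ccc(Cl)c(Cl)c2)c2ccccc2n1` differs from compound 3 by chloro in place of hydrogen on an aromatic carbon. For the measured compounds named here, the steps that bear on this are the halogen swaps a 1.4-fold lower number from compound 1 to compound 2 (0.16 log units; within the scatter), a 1.5-fold lower number from compound 1 to compound 3 (0.18 log units; within the scatter) and a 1.1-fold lower number from compound 2 to compound 3 (0.02 log units; within the scatter), none of which moved the number beyond the scatter. A further chloro is therefore expected to give no step beyond the scatter, a 1.1-fold lower number from compound 3 to compound 4 (0.05 log units; within the scatter). For compound 4 the estimate is 480 10^-6 cm/s, with a range of 240 10^-6 cm/s to 960 10^-6 cm/s.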

Compound 4, apparent permeability: 197 10^-6 cm/s
Estimate against measurement, compound 4: 2.4-fold (0.39 log units) above; measured number outside the range, below it.
By their numbers in this assay, from the lowest: compound 4; then compounds 3, 2 and 1 (each within the scatter of the next).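

Swapping one halogen for another on this ring stayed within the scatter, but adding a second chloro, ortho to a chloro group, does not: this assay shows a 2.7-fold lower number from compound 3 to compound 4 (0.44 log units; beyond the scatter) and a 2.9-fold lower number from compound 2 to compound 4 (0.46 log units; beyond the scatter). Starting from either single-chloro compound, the same added atom lowers the number by a modest but readable step. Nothing available here gives a reason for this step. Still open, going by these compounds, is whether a methoxy group or an amine on that same carbon would give a similar step, and whether a second chloro elsewhere on the ring would.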